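This account rests on a few compounds, and the source may have more. Where it says the series, first, only, none or still open, it means among the compounds named here.

Compound 2 `CCC(=O)NCc1cncc(N2C(=O)c3ccc(Cl)cc3C2(C)C)c1` gives 282 nM in an assay on cells for inhibition of cytochrome P450 11B2, mitochondrial (Homo sapiens), read by HTRF; a higher number here means a weaker inhibitor, a lower number a stronger inhibitor.
Compound 1 `CC(=O)N[C@@H]1CCCc2c1cncc2N1C(=O)c2ccc(Cl)cc2[C@@H]1C1CC1` gives 354 nM in this assay.
Compound 3 `Cc1cccnc1C(=O)NCc1cncc(N2C(=O)c3ccc(Cl)cc3C2(C)C)c1` gives 9 nM in this assay.

Among these three numbers compound 2 stands second highest. Compound 1 sits within the scatter of it, so the two cannot be told apart; compound 3 sits far lower, a change of a 31-fold lower number from compound 2 to compound 3 (1.50 log units; beyond the scatter), brought about by 3-methylpyridin-2-yl in place of ethyl on a carbonyl carbon.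

Compound 4 `CC(=O)N1CC[C@H](Oc2cncc(N3C(=O)c4ccc(Cl)cc4C3(C)C)c2)C1` has not yet been measured. It differs from compound 2 by a group of 9 heavy atoms (6 carbon, 1 nitrogen, 2 oxygen; one five-membered non-aromatic ring with 1 hetero atom) in place of a group of 6 heavy atoms (4 carbon, 1 nitrogen, 1 oxygen; no ring), on an aromatic carbon. Going by the values given here, this is a different kind of change from the one measured step: there the carbonyl and its attached amide were kept and only the group on the carbonyl carbon grew; here the whole (propanoylamino)methyl arm, with its hydrogen-bond donor, is exchanged for a ring-containing group joined through an oxygen. Among the compounds with values here, no measured step shows such an exchange, so the one large step from compound 2 to compound 3 offers only a loose guide and does not point to a direction for compound 4.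

With that in mind, compound 4 is expected to give about 350 nM in this assay, somewhere between 90 nM and 1400 nM, which would amount to an estimated step of a 1.2-fold higher number from compound 2 to compound 4 (0.09 log units; within the scatter), not clearly beyond the scatter.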

Compound 4, half-maximal inhibitory concentration: 7 nM
The estimate for compound 4 lay 50-fold (1.70 log units) above the measured number; the measured number lies below the stated range.
By their numbers in this assay, from the lowest: compounds 4 and 3 (each within the scatter of the next); then compounds 2 and 1 (each within the scatter of the next).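

In this assay, swapping the whole (propanoylamino)methyl arm on this aromatic carbon for a ring-containing group joined through an oxygen gives a 40-fold lower number from compound 2 to compound 4 (1.61 log units; beyond the scatter), so a large drop here does not require keeping that arm and enlarging the group on its carbonyl carbon. Compound 3 keeps the amide hydrogen of the arm, while the group entering compound 4 has no hydrogen-bond donor, yet compound 3 at 9 nM and compound 4 at 7 nM lie within the scatter of each other, so a low number at this position does not depend on that donor. Going by these compounds alone, nothing available here explains why the new group lowers the number so far.

From the compounds shown here alone, it remains open which part of the entering group matters: the linking oxygen, the five-membered ring, the acetyl group on its nitrogen, or the defined stereocentre. A plain methoxy group on the same aromatic carbon, the same ring with methanesulfonyl in place of acetyl, and the opposite configuration at the stereocentre would each help separate these parts.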